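A Single Aryl Swap on the Urea Nitrogen

This account rests on a few compounds, and the source may have more. Where it says the series, first, only, none or still open, it means among the compounds named here.

Measured so far, in a functional assay on MOLT-4 cells (Homo sapiens) for inhibition, read by sulforhodamine B assay, with a stated time of 48 h; a higher number here means a weaker inhibitor of growth, a lower number a stronger inhibitor of growth:
- compound 1 `O=C(Nc1cccc(-n2cc(-c3ccncc3)c(-c3ccc(Cl)c(O)c3)n2)c1)Nc1cccc(C(F)(F)F)c1`: > 32500 nM, which is a limit of the assay and not a number
- compound 2 `COc1cc(-c2nn(-c3cccc(NC(=O)Nc4cc(C(F)(F)F)cc(C(F)(F)F)c4)c3)cc2-c2ccncc2)ccc1Cl`: 4480 nM
- compound 3 `COc1cc(-c2nn(-c3cccc(NC(=O)Nc4ccc(Cl)c(Cl)c4)c3)cc2-c2ccncc2)ccc1Cl`: 4480 nM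

Compound 3 sits level with compound 2 at the digits shown; the two values are within the usual scatter, so neither can be called the stronger. Within the data shown here, compound 1 is the one value that is only a limit (the limit of > 32500 nM in this assay, at which 1 of the 3 values shown sits), and it stands apart from the other two.

Compound 4 `COc1cc(-c2nn(-c3cccc(NC(=O)Nc4cccc(C(F)(F)F)c4)c3)cc2-c2ccncc2)ccc1Cl` has not yet been measured. It differs from compound 3 in one place: 3-(trifluoromethyl)phenyl in place of 3,4-dichlorophenyl on an amide-type nitrogen. Both groups carry no hydrogen-bond donors or acceptors, and the change sits on the same amide-type nitrogen of the shared core.

Among the measured compounds shown here, no measured pair differs at exactly this position, so the size of the step is open. Compound 4 is expected to land near compound 3, with the step of a 1.6-fold higher number from compound 3 to compound 4 (0.19 log units; within the scatter) estimated to stay within the scatter, leaning slightly toward weaker growth inhibition. The estimate for compound 4 in this assay is 7000 nM, with a range from 2500 nM to 32500 nM.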

Compound 4, concentration for total growth inhibition: 3480 nM
Estimate against measurement, compound 4: 2.0-fold (0.30 log units) above, and the stated range covers the measured number.
By their numbers in this assay, from the lowest: compounds 4, 2 and 3 (each within the scatter of the next). At a limit, above all of these: compound 1.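

In this assay, the aryl group on this amide-type nitrogen can change without a readable effect: swapping 3,4-dichlorophenyl for 3-(trifluoromethyl)phenyl gives a 1.3-fold lower number from compound 3 to compound 4 (0.11 log units; within the scatter), and removing one trifluoromethyl gives a 1.3-fold lower number from compound 2 to compound 4 (0.11 log units; within the scatter), so compounds 2, 3 and 4 cannot be told apart here. Among these compounds, the one step beyond the scatter lies elsewhere, where methyl takes the place of hydrogen on an oxygen on an aromatic ring: an at least 9.3-fold lower number from compound 1 to compound 4 (0.97 log units; beyond the scatter). The value of compound 1 is a limit of the assay, so this step has no exact size: the limit of > 32500 nM in this assay, at which 1 of the 4 values shown sits.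

On these data alone, only substituted phenyl groups appear on this nitrogen, so it remains open whether a phenyl carrying an amine or a carboxylic acid, or a plain alkyl chain in its place, would hold this level. It is also unknown how an ethyl group on that oxygen would compare with methyl.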